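The compounds below may be only part of what the source reports. "The series", "measured", "known", "first", "only" and "open" are said of these compounds alone.

Measured in a functional assay on B16 cells (Mus musculus) for cytotoxicity, read by CCK-8 assay, with a stated time of 24 h; a higher number here means a weaker inhibitor, a lower number a stronger inhibitor:
- compound 1 `COc1ccccc1Oc1c(N)nc(-c2ccc(Cl)cc2)nc1Cl`: 18800 nM
- compound 2 `COc1ccccc1Oc1c(N)nc(-c2ccc(C)cc2)nc1OCCO`: 8430 nM
- compound 3 `COc1ccc(-c2nc(N)c(Oc3ccccc3OC)c(OCCO)n2)cc1`: 18100 nM

Compound 3 is level with compound 1 within the scatter, and both values lie above that of compound 2. The next compound is compound 4 `COc1ccccc1Oc1c(N)nc(-c2ccc(Cl)cc2)nc1OCCO`, which differs from compound 3 as follows: chloro in place of methoxy on an aromatic carbon. This is chloro in place of methoxy on an aromatic carbon, para to a large group, so 4-methoxyphenyl becomes 4-chlorophenyl.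

Among the compounds with values here, only one measured step acts at this place, methoxy in place of methyl, and it is modest. Within the data shown here, compound 1 carries the 4-chlorophenyl but differs elsewhere, so its 18800 nM gives no direct step. With a 2.1-fold higher number from compound 2 to compound 3 (0.33 log units; beyond the scatter) as the guide, a step no larger is expected in this assay, probably toward a lower number, and it may stay within the scatter. The estimated step is a 1.5-fold lower number from compound 3 to compound 4 (0.18 log units; within the scatter). For compound 4 the expected value is 12000 nM, with an estimated range of 6000 nM to 24000 nM.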

Compound 4, half-maximal inhibitory concentration: 7740 nM
Compound 4: the middle estimate sits 1.6-fold (0.19 log units) above what was measured; the range from low to high includes it.
By their numbers in this assay, from the lowest: compounds 4 and 2 (each within the scatter of the next); then compounds 3 and 1 (each within the scatter of the next).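

In this assay the change from 4-methoxyphenyl to 4-chlorophenyl gives a 2.3-fold lower number from compound 3 to compound 4 (0.37 log units; beyond the scatter) and so shows that the group at this place can move the number beyond the scatter. Chloro in place of methyl gives a 1.1-fold lower number from compound 2 to compound 4 (0.04 log units; within the scatter) and leaves these two groups level, so among the three groups tested here methoxy alone goes with the higher number. Compound 4 also gives the first direct read on the other varied place, where 2-hydroxyethoxy in place of chloro gives a 2.4-fold lower number from compound 1 to compound 4 (0.39 log units; beyond the scatter) with the 4-chlorophenyl held constant.

From the compounds shown here alone, it remains open whether an amine or a carboxylic acid at the place of the 2-hydroxyethoxy group, or a longer chain there, would shift the number further. No supporting measurement is available to explain these steps.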